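The source may report more compounds than this note shows. Statements on the series, on what has been measured and on what is new or still open speak of the compounds shown alone.

Measured so far in a functional assay on COLO 205 cells (Homo sapiens) for inhibition, read by sulforhodamine B assay, with a stated time of 48 h; on this read-out lower numbers stand for stronger inhibition of growth and higher numbers for weaker inhibition of growth:
compound 1, `COc1ccc(-c2[nH]c3ccccc3c2/C=C(\C#N)S(=O)(=O)c2ccccc2)cc1`: 254 nM
compound 2, `N#C/C(=C\c1c(-c2ccccc2)[nH]c2ccccc12)S(=O)(=O)c1ccccc1`: 1400 nM

Going by the values given here, compound 2 holds the higher of the two numbers in this assay; the only measured step, a 5.5-fold higher number from compound 1 to compound 2 (0.74 log units; beyond the scatter), concerns a methoxy group and not the chain. Compound 3, `N#C/C(=C\c1c(-c2ccccc2)[nH]c2ccccc12)C(=O)c1ccccc1`, differs from compound 2 by benzoyl in place of phenylsulfonyl on a double-bonded chain carbon bound to a double-bonded chain carbon and a triple-bonded carbon. Among the compounds with values here, no measured step bears on this change, so nothing here points in either direction. The step from compound 2 to compound 3 is expected to be a 1.8-fold higher number from compound 2 to compound 3 (0.25 log units; within the scatter), leaning toward a weaker compound. Compound 3 is expected to give 2500 nM in this assay, within a range of 800 nM to 8000 nM.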

Compound 3, concentration for 50% growth inhibition: 5000 nM
Estimate against measurement, compound 3: 2.0-fold (0.30 log units) below; measured number inside the range.
By their numbers in this assay, from the lowest: compound 1; then compound 2; then compound 3.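

In this assay, the double-bonded chain carbon bound to a double-bonded chain carbon and a triple-bonded carbon proves sensitive to its substituent: benzoyl in place of phenylsulfonyl weakens growth inhibition beyond the scatter (a 3.6-fold higher number from compound 2 to compound 3 (0.55 log units; beyond the scatter)). Going by these compounds alone, this is the first reading at this place, since the earlier step concerned only methoxy. Nothing at hand explains the loss.

Going by these compounds, whether methoxy on the aromatic carbon would give a similar gain alongside benzoyl remains open. So does how an ethyl ester or a carboxamide would compare at this place.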